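Iodo in place of furan-3-yl on compound 3

This account rests on a few compounds, and the source may have more. Where it says the series, first, only, none or still open, it means among the compounds named here.

compound 1 `CSc1ncnc2c1c(-c1ccoc1)cn2[C@@H]1O[C@H](CO)[C@@H](O)[C@H]1O`: 14200 nM
compound 2 `CNc1ncnc2c1c(-c1ccoc1)cn2[C@@H]1O[C@H](CO)[C@@H](O)[C@H]1O`: > 20000 nM (a limit)
compound 3 `Cc1ncnc2c1c(-c1ccoc1)cn2[C@@H]1O[C@H](CO)[C@@H](O)[C@H]1O`: > 20000 nM (a limit)

In a functional assay on CCRF-CEM cells (Homo sapiens), read by MTT assay, with a stated time of 72 h (a lower number here means a stronger inhibitor, a higher number a weaker inhibitor), compound 3 gives > 20000 nM, which is a limit of the assay and not a number. That is the limit of > 20000 nM in this assay, at which 2 of the 3 values shown sit. Compound 4 `Cc1ncnc2c1c(I)cn2[C@@H]1O[C@H](CO)[C@@H](O)[C@H]1O` keeps the rest of compound 3 and differs in one place: iodo in place of furan-3-yl on an aromatic carbon.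

Going by the values given here, all three measured compounds carry furan-3-yl, so no measured step tests this change directly. The steps available are an at least 1.4-fold higher number from compound 1 to compound 2 (0.14 log units; that floor lies within the scatter), an at least 1.4-fold higher number from compound 1 to compound 3 (0.14 log units; that floor lies within the scatter) and a step that the two limits leave unreadable from compound 2 to compound 3. They give no size to carry over to the new change. Compound 3 has only a limit, so any readable number for compound 4 in this assay would have to be a lower one. The direction expected is therefore towards a lower number, of uncertain size, and another limit remains quite possible. The expected step is an at least 4.0-fold lower number from compound 3 to compound 4 (0.60 log units; beyond the scatter). For compound 4 the estimate is 5000 nM, with an expected range from 400 nM to 20000 nM.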

Compound 4, half-maximal inhibitory concentration: 5480 nM
Beside the measured number, compound 4's estimate is 1.1-fold (0.04 log units) below it; low and high end bracket the measured number.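

Replacing furan-3-yl with iodo gives an at least 3.6-fold lower number from compound 3 to compound 4 (0.56 log units; beyond the scatter) in this assay, the only step shown that lies beyond the scatter. The earlier compounds shown here all carried furan-3-yl and differed only in a group elsewhere on the core, so they said nothing about this aromatic carbon; this step shows that the group placed here can move the read-out, and that a single iodine atom without a ring gives a readable number where the furan-3-yl compound 3 does not. The true size of the step may be larger, since compound 3 has a limit of the assay and not a number, so the step gives only a floor: the limit of > 20000 nM in this assay, at which 2 of the 4 values shown sit.

As far as these compounds go, with only furan-3-yl and iodo at this position, it remains open whether the gain belongs to iodine itself or would also appear with bromo, chloro, an ethynyl group or a plain hydrogen. From the compounds shown here alone, it is also open how iodo behaves alongside the methylsulfanyl of compound 1 or the methylamino of compound 2, and the step between compound 2 and compound 3 cannot be read.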